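Bromo for methyl on the core of compound 3

The compounds below may be only part of what the source reports. "The series", "measured", "known", "first", "only" and "open" are said of these compounds alone.

Measured so far in a functional assay for binding affinity to metabotropic glutamate receptor 2 (Homo sapiens), read by GTPgammaS binding, with a stated time of 1 h, at 30 degrees C; on this read-out higher numbers stand for an effect only at larger amounts of compound and lower numbers for an effect already at smaller amounts:
compound 1 `CCCc1c(OCCCCOc2ccc(-c3nn[nH]n3)cc2)ccc2c1ccn2CC(C)(C)C` gives 559 nM
compound 2 `CC(C)(C)Cn1ccc2cc(OCCCCOc3ccc(-c4nn[nH]n4)cc3)ccc21` gives 3590 nM
compound 3 `Cc1c(OCCCCOc2ccc(-c3nn[nH]n3)cc2)ccc2c1ccn2CC(C)(C)C` gives 1070 nM

Compound 3 stands second highest of the three numbers; its nearest neighbour is compound 1, with a 1.9-fold higher number from compound 1 to compound 3 (0.28 log units; within the scatter), a step within the scatter, and its furthest is compound 2, with a 3.4-fold lower number from compound 2 to compound 3 (0.53 log units; beyond the scatter), a step beyond the scatter.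

Compound 4 `CC(C)(C)Cn1ccc2c(Br)c(OCCCCOc3ccc(-c4nn[nH]n4)cc3)ccc21` differs from compound 3 by bromo in place of methyl on an aromatic carbon. Among the measured compounds shown here, no measured step exchanges a carbon substituent for a halogen at this carbon, so the bearing steps are indirect: a 3.4-fold lower number from compound 2 to compound 3 (0.53 log units; beyond the scatter) shows that placing a group at this carbon lowers the number beyond the scatter, and a 1.9-fold higher number from compound 1 to compound 3 (0.28 log units; within the scatter) shows that the size of that group, within the range covered, changes little. Bromo, a single heavy atom like methyl, is expected to keep the number near that of compound 3, with perhaps a small lowering.

For compound 4 the estimate in this assay is 800 nM, with a range of 300 nM to 2500 nM, which means an expected step of a 1.3-fold lower number from compound 3 to compound 4 (0.13 log units; within the scatter).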

Compound 4, half-maximal effective concentration: 2260 nM
Compound 4: middle estimate off by 2.8-fold (0.45 log units), on the low side; low and high end bracket the measured number.
By their numbers in this assay, from the lowest: compounds 1 and 3 (each within the scatter of the next); then compounds 4 and 2 (each within the scatter of the next).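

In this assay, bromo on this aromatic carbon does not act as a simple stand-in for methyl: the exchange gives a 2.1-fold higher number from compound 3 to compound 4 (0.32 log units; beyond the scatter), and the exchange for hydrogen gives only a 1.6-fold lower number from compound 2 to compound 4 (0.20 log units; within the scatter), whereas compound 1 and compound 3, with propyl and methyl at this carbon, both stand beyond the scatter of compound 2. Occupying this carbon with a single heavy atom is therefore not sufficient on its own; what the atom is also counts, and the exchange of propyl for bromo gives a 4.0-fold higher number from compound 1 to compound 4 (0.61 log units; beyond the scatter). No measurement on hand accounts for the difference between bromo and the carbon groups.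

Going by these compounds, whether chloro, methoxy or a nitrile at this carbon would track bromo or the carbon groups remains open. Also open, on these data alone, is whether the gap between bromo and methyl would persist with a longer chain in place of the one shared by all four compounds.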